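Chloro to fluoro on the benzamido member of the series

The source may report more compounds than this note shows. Statements on the series, on what has been measured and on what is new or still open speak of the compounds shown alone.

Of the compounds shown here, three on one shared core have been measured so far. Compound 1 `O=C(Nn1c(-c2cccc([N+](=O)[O-])c2)nc2c(-c3ccc(Cl)cc3)n[nH]c2c1=O)c1cccnc1` carries a 4-chlorophenyl and a (pyridin-3-yl)carbonyl; in a functional assay on HT-29 cells (Homo sapiens) for cytotoxicity, read by sulforhodamine B assay, with a stated time of 2 days, tested at 100 uM (on this read-out higher numbers stand for more inhibition at the one concentration tested (going by the name of the read-out) and lower numbers for less inhibition), compound 1 gives 15.1%. Compound 2 `O=C(Nn1c(-c2cccc([N+](=O)[O-])c2)nc2c(-c3ccc(F)cc3)n[nH]c2c1=O)c1cccnc1` differs from compound 1 by fluoro in place of chloro on an aromatic carbon; in this assay compound 2 gives 24.7%, and the step is a number 9.6 percentage points higher from compound 1 to compound 2 (within the scatter). Compound 3 `O=C(Nn1c(-c2cccc([N+](=O)[O-])c2)nc2c(-c3ccc(Cl)cc3)n[nH]c2c1=O)c1ccccc1` differs from compound 1 by phenyl in place of pyridin-3-yl on a carbonyl carbon; in this assay compound 3 gives 87.8%, the step being a number 72.7 percentage points higher from compound 1 to compound 3 (beyond the scatter), and compound 3 stands clearly above both compound 1 and compound 2.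

Compound 4 `O=C(Nn1c(-c2cccc([N+](=O)[O-])c2)nc2c(-c3ccc(F)cc3)n[nH]c2c1=O)c1ccccc1` is not yet measured. It differs from compound 3 by fluoro in place of chloro on an aromatic carbon, the same change already seen from compound 1 to compound 2, at a place described in identical words, so it is the same change made a second time, on the benzamido rather than the ((pyridin-3-yl)carbonyl)amino pair.

Because the earlier step of a number 9.6 percentage points higher from compound 1 to compound 2 (within the scatter) stayed within the scatter, the step from compound 3 to compound 4 is expected to be small as well, a number 2.8 percentage points lower from compound 3 to compound 4 (within the scatter). Compound 4 is therefore estimated at 85%, with a range from 65% to 98%.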

Compound 4, a percentage reported as inhibition, at one concentration (the size of the read-out at that concentration, not a potency): 92%
Compound 4: middle estimate off by 7 percentage points, on the low side; measured number inside the range.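

In this assay, fluoro in place of chloro again gives a small step, a number 4.2 percentage points higher from compound 3 to compound 4 (within the scatter), and the two occurrences agree: the same change on two cores in this assay, a number 9.6 percentage points higher (within the scatter) from compound 1 to compound 2 and a number 4.2 percentage points higher (within the scatter) from compound 3 to compound 4, 5.4 percentage points apart, within the scatter of two such steps. Phenyl in place of pyridin-3-yl on the carbonyl carbon again gives a large step, a number 67.3 percentage points higher from compound 2 to compound 4 (beyond the scatter), and its size also carries across from the chloro pair to the fluoro pair: the same change on two cores in this assay, a number 72.7 percentage points higher (beyond the scatter) from compound 1 to compound 3 and a number 67.3 percentage points higher (beyond the scatter) from compound 2 to compound 4, 5.4 percentage points apart, within the scatter of two such steps. Within these four compounds, each change therefore reads the same whichever form the other place takes, but this rests on a single repeat of each change at one concentration and shows neither potency nor transfer to any other core.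

Still open, as far as these compounds go, is whether the large step is specific to pyridin-3-yl against phenyl, or also appears with a pyridin-4-yl, a methyl or a longer alkyl chain on the carbonyl. Also open, from the compounds shown here alone, is how the read-out responds to a methoxy group in place of the halogen, or to an amine or a carboxylic acid in place of the nitro group.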